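The compounds below may be only part of what the source reports. "The series", "measured", "known", "first", "only" and "open" are said of these compounds alone.

In a functional assay on HT-29 cells (Homo sapiens) for cytotoxicity, read by MTT assay, with a stated time of 72 h (a higher number here means a weaker inhibitor, a lower number a stronger inhibitor), compound 1 `CN1C/C(=C\c2ccc(F)c(F)c2)C(=O)/C(=C/c2ccc(F)c(F)c2)C1` gives 1500 nM, and compound 2 `CN1C/C(=C\c2cc(F)c(F)cc2F)C(=O)/C(=C/c2cc(F)c(F)cc2F)C1` gives 840 nM. Compound 3 `CN1C/C(=C\c2c(F)cc(F)cc2F)C(=O)/C(=C/c2c(F)cc(F)cc2F)C1` has no numerical value, only a limit of > 10000 nM. For the measured compounds named here, no measured step connects compound 3 to either of the other two through a single change.

Compound 4 `CCN1C/C(=C\c2c(F)cc(F)cc2F)C(=O)/C(=C/c2c(F)cc(F)cc2F)C1` differs from compound 3 by one change, methyl in place of hydrogen on a saturated chain carbon bound to an amine nitrogen in a ring, or methyl to ethyl when cut one bond further out. Going by the values given here, no measured step shows the size of this change, so no shift beyond the scatter is expected in this assay, and no direction is favoured. This expectation rests on compound 3, whose reading of > 10000 nM is a limit. The expected step of a number no higher from compound 3 to compound 4 (the limit leaves the size open) is estimated to stay within the scatter. Compound 4 is estimated at 10000 nM, with an expected range of 3000 nM to 30000 nM.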

Compound 4, half-maximal inhibitory concentration: 2000 nM
The estimate for compound 4 lay 5.0-fold (0.70 log units) above the measured number; measured number outside the range, below it.
By their numbers in this assay, from the lowest: compounds 2, 1 and 4 (each within the scatter of the next, the first and the last beyond it). At a limit, above all of these: compound 3.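

In this assay, methyl in place of hydrogen on a saturated chain carbon bound to an amine nitrogen in a ring gives an at least 5.0-fold lower number from compound 3 to compound 4 (0.69 log units; beyond the scatter). For the compounds shown here, this is the first measured step at this place, and it shows that the methyl to ethyl change alone, with the rest of the structure unchanged, can bring a compound from a limit to a number. Compound 3 gives > 10000 nM, which is a limit and not a number, so the true size of the step stays unknown: the limit of > 10000 nM in this assay, at which 1 of the 4 values shown sits.

From the compounds shown here alone, it remains open whether the same methyl to ethyl change shifts the read-out on the core of compound 1 or of compound 2. Going by these compounds, it is also open how a longer chain such as propyl, or a benzyl group, would read at this place.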